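The source may report more compounds than this note shows. Statements on the series, on what has been measured and on what is new or still open speak of the compounds shown alone.

Measured so far:
compound 1, `Cn1c(=O)c(=O)n(Cc2ccccc2C#N)c2c(N3CCC[C@@H](N)C3)ccnc21`: > 100000 nM
compound 2, `Cn1c(=O)n(Cc2ccccc2C#N)c2c(N3CCC[C@@H](N)C3)ncnc21`: > 100000 nM
compound 3, `Cn1c(=O)n(Cc2ccccc2C#N)c2c(N3CC[C@@H](N)C3)ccnc21`: > 100000 nM

Of the compounds shown here, three have been tested in an assay on isolated protein for inhibition of Dipeptidyl peptidase 9 (Homo sapiens), read by luminescence, with a stated time of 15 min; on this read-out higher numbers stand for weaker inhibition and lower numbers for stronger inhibition. In this assay compound 1 gives > 100000 nM, which is a limit of the assay rather than a measured number. In this assay compound 2 gives > 100000 nM, again only a limit. In this assay compound 3 gives > 100000 nM, also a limit.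

So compound 3 does not stand at a number at all: its value is a limit, and the two other values shown are limits as well. For the measured compounds named here, all three sit at the limit of > 100000 nM in this assay, at which 3 of the 3 values shown sit, so no difference between any pair of them can be read from these data, and no step between measured compounds is available.

Compound 4, `Cn1c(=O)n(Cc2ccccc2C#N)c2c(N3CCCCC(N)C3)ccnc21`, has not yet been measured. It differs from compound 3 in one place: 3-aminoazepan-1-yl in place of 3-aminopyrrolidin-1-yl on an aromatic carbon. Going by the values given here, because every value so far rests at the limit of > 100000 nM in this assay, at which 3 of the 3 values shown sit, there is nothing in the shared core or its varied side groups that has yet pulled a compound into the measurable range. Compound 4 is therefore expected to give about 100000 nM, with a range from 30000 nM to 300000 nM. The step of a number no higher from compound 3 to compound 4 (the limit leaves the size open) is expected to be none beyond the usual scatter, with the assay most likely again reporting only a limit.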

Compound 4, half-maximal inhibitory concentration: > 100000 nM
Compound 4: only a limit was reported (the forecaster's own chance of this, stated with the estimate: 80%); the middle value sits exactly at the limit.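

In this assay compound 4 gives > 100000 nM, which is a limit and not a number. Compound 3 also gives only a limit, so no step from compound 3 to compound 4 can be read: the limit of > 100000 nM in this assay, at which 4 of the 4 values shown sit.

The compounds shown leave open how strongly any of them inhibits the enzyme, and whether 3-aminoazepan-1-yl and 3-aminopyrrolidin-1-yl differ at all.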